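A 2-Chlorophenyl Variant of a Weakly Active Anilino Core

This account rests on a few compounds, and the source may have more. Where it says the series, first, only, none or still open, it means among the compounds named here.

Among the compounds with values here, compound 1 `C#CCSc1nc(Nc2ccc(OC)cc2)c(C#N)c(-c2ccccc2)n1` holds the only numerical reading here: in a functional assay on ECa-109 cells (Homo sapiens) for inhibition, read by MTT assay, with a stated time of 72 h (on this read-out lower numbers stand for stronger inhibition and higher numbers for weaker inhibition), compound 1 gives 23200 nM. Compound 2 `C#CCSc1nc(Nc2cccc(C(F)(F)F)c2)c(C#N)c(-c2ccccc2)n1` sits at an assay limit, giving > 128000 nM in this assay. The unmeasured compound 3 `C#CCSc1nc(Nc2ccccc2Cl)c(C#N)c(-c2ccccc2)n1` differs from compound 1 by 2-chlorophenyl in place of 4-methoxyphenyl on a nitrogen on an aromatic ring. Within the data shown here, no measured step joins this pair, so its size must be estimated. Since compound 2 already rests at the limit of > 128000 nM in this assay, at which 1 of the 2 values shown sits, a modest loss beyond the scatter is expected, the estimated step being a 1.9-fold higher number from compound 1 to compound 3 (0.29 log units; within the scatter). Compound 3 is therefore expected to give about 45000 nM, within 12000 nM to 160000 nM.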

Compound 3, half-maximal inhibitory concentration: > 128000 nM
Compound 3 was reported as a limit; the forecaster's own chance of this, stated with the estimate: 40%; middle value at least 2.8-fold (0.45 log units) from the limit.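

Within the data shown here, the swap of 4-methoxyphenyl for 2-chlorophenyl on the nitrogen gives the first readable step at this position: in this assay it is an at least 5.5-fold higher number from compound 1 to compound 3 (0.74 log units; beyond the scatter). Compound 3 gives > 128000 nM, which is a limit of the assay, so the step has a floor but no known size. This position thus affects the reading, and compound 1 remains the only compound with a numerical value: the limit of > 128000 nM in this assay, at which 2 of the 3 values shown sit.

Left open is whether the step follows the chlorine, its place on the ring or the loss of the methoxy group. A 4-chlorophenyl or a 2-methoxyphenyl on the same nitrogen would separate these.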